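Selenium for Sulfur on a Bis-Acylated Isothiourea Core

This account rests on a few compounds, and the source may have more. Where it says the series, first, only, none or still open, it means among the compounds named here.

Of the compounds shown here, two have been tested in a functional assay on PC-3 cells (Homo sapiens) for cytotoxicity, read by MTT assay (a lower number here means a stronger inhibitor, a higher number a weaker inhibitor), and neither reached a measurable number. Compound 1, `CC(C)[Se]/C(=N\C(=O)c1ccccc1)NC(=O)c1ccccc1`, carries an isopropylselanyl group on the shared core and gives > 10000 nM, a limit of the assay rather than a value. Compound 2, `CS/C(=N\C(=O)c1ccc(Cl)cc1)NC(=O)c1ccc(Cl)cc1`, with a methylsulfanyl group and a chlorine on each aromatic ring, also gives > 10000 nM in this assay, again a limit. Compound 2 therefore stands at the limit of > 10000 nM in this assay, at which 2 of the 2 values shown sit, with nothing to rank it against. Compound 3, `C[Se]/C(=N\C(=O)c1ccc(Cl)cc1)NC(=O)c1ccc(Cl)cc1`, differs from compound 2 by a group of 2 heavy atoms (1 carbon, 1 selenium; no ring) in place of a group of 2 heavy atoms (1 carbon, 1 sulfur; no ring), on a carbon with a double bond to nitrogen. Since compound 1 already shows that a selenium analogue of this core sits at the same limit, no step beyond the scatter is expected in either direction, and the account expects the step from compound 2 to compound 3 to be a step that the limit leaves unreadable from compound 2 to compound 3. Compound 3 is therefore estimated at 15000 nM, with a range from 4000 nM to 60000 nM, most likely reported only as a limit.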

Compound 3, half-maximal inhibitory concentration: 7600 nM
Estimate against measurement, compound 3: 2.0-fold (0.30 log units) above; measured number inside the range.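

Compound 3 is the first compound shown here to give a measured number rather than a limit, with 7600 nM in this assay. Placing the selenium group in place of methylsulfanyl, on a carbon with a double bond to nitrogen, gives an at least 1.3-fold lower number from compound 2 to compound 3 (0.11 log units; that floor lies within the scatter), so the change is not shown to matter beyond the usual variation between repeat measurements, although a larger real step is not excluded. Compound 2 is recorded only as a limit, which leaves the true size of the step unread: the limit of > 10000 nM in this assay, at which 2 of the 3 values shown sit.

From the compounds shown here alone, how far the two compounds actually lie apart remains open. So does whether an amine or a longer chain at this carbon, in place of methylsulfanyl, would bring a number clearly lower than that of compound 3.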